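This account rests on a few compounds, and the source may have more. Where it says the series, first, only, none or still open, it means among the compounds named here.

Measured so far:
- compound 1 `N/C(=N\NC(=S)N1CCOCC1)c1ccccn1`
- compound 2 `Cc1ccnc(/C(N)=N/NC(=S)N2CCOCC2)c1`
- compound 3 `Cc1ccnc(/C(N)=N/NC(=S)N2CCN(c3ccccn3)CC2)c1`

In a functional assay on A-375 cells (Homo sapiens) for cytotoxicity, read by MTT assay, with a stated time of 72 h (a higher number here means a weaker inhibitor, a lower number a stronger inhibitor), compound 1 gives 680 nM, compound 2 gives 1600 nM and compound 3 gives 780 nM. Compound 1 has the lowest number of the three; compound 3 lies within the scatter of it, while the step of a 2.4-fold higher number from compound 1 to compound 2 (0.37 log units; beyond the scatter) is beyond the scatter.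

Compound 4 `N/C(=N\NC(=S)N1CCSCC1)c1ccccn1` differs from compound 1 by thiomorpholin-4-yl in place of morpholin-4-yl on a thiocarbonyl carbon. For the measured compounds named here, no measured step bears on this change: the only measured step, a 2.4-fold higher number from compound 1 to compound 2 (0.37 log units; beyond the scatter), concerns an aromatic carbon and not the thiocarbonyl carbon. The expectation for compound 4 is therefore no step beyond the scatter, a 1.0-fold lower number from compound 1 to compound 4 (0.02 log units; within the scatter). Compound 4 is estimated at 650 nM, with a range of 280 nM to 1500 nM.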

Compound 4, half-maximal inhibitory concentration: 760 nM
Compound 4: the middle estimate sits 1.2-fold (0.07 log units) below what was measured; measured number inside the range.
By their numbers in this assay, from the lowest: compounds 1, 4 and 3 (each within the scatter of the next); then compound 2.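

For the compounds shown here, on the thiocarbonyl carbon, thiomorpholin-4-yl in place of morpholin-4-yl is the first change read at this position, and in this assay it gives a 1.1-fold higher number from compound 1 to compound 4 (0.05 log units; within the scatter). Exchanging the ring oxygen for sulfur therefore leaves the number of compound 1 within the scatter. Nothing measured here offers an explanation for this result.

Still open, as far as these compounds go, is whether an open-chain amine such as dimethylamino on the thiocarbonyl carbon would keep the number within the scatter. Also open, from the compounds shown here alone, is whether methyl on an aromatic carbon gives the same step with thiomorpholin-4-yl as with morpholin-4-yl.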